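A few compounds are considered here, and "the series" means these few. Any claim that something is new, unique, unknown or untested is made for them only; others in the source may bear on it.

Three acylated variants of one shared core were tested in a functional assay on A549 cells (Homo sapiens) for cytotoxicity, read by MTT assay, with a stated time of 48 h; on this read-out higher numbers stand for weaker inhibition and lower numbers for stronger inhibition. Compound 1 `C=C1C(=O)O[C@H]2CC3=C[C@H](C/C(C)=C/[C@@H](OC(=O)CCCCBr)[C@H]12)OC3=O` reads > 10000 nM, which is a limit of the assay and not a number. Compound 2 `C=C1C(=O)O[C@H]2CC3=C[C@H](C/C(C)=C/[C@@H](OC(=O)CCl)[C@H]12)OC3=O` reads > 10000 nM, again a limit. Going by the values given here, compound 3 `C=C1C(=O)O[C@H]2CC3=C[C@H](C/C(C)=C/[C@@H](OC(=O)C4CCC(F)(F)CC4)[C@H]12)OC3=O` gives 6400 nM, the only true number in the set.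

The next step goes to compound 4 `C=C1C(=O)O[C@H]2CC3=C[C@H](C/C(C)=C/[C@@H](OC(=O)C(C)(C)CC)[C@H]12)OC3=O`, with 1,1-dimethylpropyl in place of 4,4-difluorocyclohexyl on a carbonyl carbon. Among the compounds with values here, two measured steps bear on this site, both arriving at the group that now leaves. They are an at least 1.5-fold lower number from compound 1 to compound 3 (0.19 log units; that floor lies within the scatter) and an at least 1.5-fold lower number from compound 2 to compound 3 (0.19 log units; that floor lies within the scatter). Neither contains the entering group, and each gives only a floor, so they offer no ground for a large move in either direction. In this assay the expected result is a 1.3-fold higher number from compound 3 to compound 4 (0.12 log units; within the scatter), which means no change beyond the scatter, though a reading at the limit remains possible. The estimated value for compound 4 is 8500 nM, with an expected range of 3500 nM to 20000 nM.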

Compound 4, half-maximal inhibitory concentration: 2200 nM
Compound 4: middle estimate off by 3.9-fold (0.59 log units), on the high side, outside the stated range (below it).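

In this assay, going by these compounds alone, the change to 1,1-dimethylpropyl gives a 2.9-fold lower number from compound 3 to compound 4 (0.46 log units; beyond the scatter), the first step at this position that has a true size and lies beyond the scatter. The same group also gives an at least 4.5-fold lower number from compound 2 to compound 4 (0.65 log units; beyond the scatter) and an at least 4.5-fold lower number from compound 1 to compound 4 (0.65 log units; beyond the scatter), though these two steps are only floors: the limit of > 10000 nM in this assay, at which 2 of the 4 values shown sit. Compound 4 is therefore the strongest of the four on this read-out, which shows that the group on this carbonyl carbon can move the result and that a ring is not needed there for a measurable value.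

The compounds shown do not separate the effect of the branched chain from that of removing halogen, as compound 4 is the only one without halogen. As far as these compounds go, whether a tert-butyl group, an unbranched pentyl chain or an amine on the acyl chain would match compound 4 remains open.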